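Adding methoxy to the biphenyl amide of compound 2

The source may report more compounds than this note shows. Statements on the series, on what has been measured and on what is new or still open speak of the compounds shown alone.

Compound 2 `O=C(CCc1cccc2c1B(O)OC2)Nc1cccc(-c2ccccc2)c1` gives 890 nM in a functional assay on HCT-116 cells (Homo sapiens) for antiproliferative activity, read by MTT assay, with a stated time of 72 h (on this read-out higher numbers stand for weaker inhibition and lower numbers for stronger inhibition), the higher of the two numbers seen; compound 1 `O=C(CCc1cccc2c1B(O)OC2)Nc1ccccc1` gives 350 nM there, and the step of a 2.5-fold higher number from compound 1 to compound 2 (0.41 log units; beyond the scatter) came with a phenyl in place of hydrogen on an aromatic carbon. Compound 3 `COc1ccc(-c2cccc(NC(=O)CCc3cccc4c3B(O)OC4)c2)cc1` differs from compound 2 by methoxy in place of hydrogen on an aromatic carbon. Going by the values given here, no measured step shows the effect of a methoxy, so the only guide is that the one change so far, attaching phenyl, moved the number modestly. For compound 3 the expected step of a 1.0-fold higher number from compound 2 to compound 3 (0.00 log units; within the scatter) is therefore small, within the scatter. Compound 3 is estimated at 900 nM, in the range 400 nM to 2000 nM.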

Compound 3, half-maximal inhibitory concentration: 160 nM
Beside the measured number, compound 3's estimate is 5.6-fold (0.75 log units) above it, outside the stated range (below it).
By their numbers in this assay, from the lowest: compound 3; then compound 1; then compound 2.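

In this assay, methoxy on the outer ring of compound 2, para to a large group, gives a 5.6-fold lower number from compound 2 to compound 3 (0.75 log units; beyond the scatter), so this position can change activity strongly. The 4-methoxyphenyl group also gives a 2.2-fold lower number from compound 1 to compound 3 (0.34 log units; beyond the scatter), so adding this larger group need not weaken inhibition, unlike plain phenyl. Nothing available explains this gain. As far as these compounds go, whether it is specific to methoxy remains open, since a hydroxyl, an amine or a chlorine at this place could behave differently. From the compounds shown here alone, the effect of methoxy elsewhere on that ring also remains open.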